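From an Aminocyclopentyl Ring to a Branched Open Chain

This account rests on a few compounds, and the source may have more. Where it says the series, first, only, none or still open, it means among the compounds named here.

Compound 3 `NC1(CN(C(=O)[C@@H]2C[C@H]2c2ccccc2)c2ccc(-c3ccccc3)cc2)CCCC1` gives the lowest number of the three compounds measured in a functional assay for agonist activity at G protein-coupled receptor 88 (Homo sapiens), read by HTRF and cAMP accumulation (a lower number here means that less compound is needed, a higher number that more compound is needed for the effect), at 0.57 nM. Compound 2 `CC[C@@H](C)[C@H](N)CN(C(=O)[C@@H]1C[C@H]1c1ccccc1)c1ccc(-c2ccccc2)cc1` stands nearest to it with 1.4 nM, and compound 1 `CC(C)C[C@H](N)CN(C(=O)[C@@H]1C[C@H]1c1ccccc1)c1ccc(-c2ccccc2)cc1` lies furthest away with 880 nM. The step of a 2.5-fold lower number from compound 2 to compound 3 (0.39 log units; beyond the scatter) is modest, whereas a 1500-fold lower number from compound 1 to compound 3 (3.19 log units; beyond the scatter) and a 630-fold lower number from compound 1 to compound 2 (2.80 log units; beyond the scatter) are both large.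

Compound 4 `CC(C)(C)[C@H](N)CN(C(=O)[C@@H]1C[C@H]1c1ccccc1)c1ccc(-c2ccccc2)cc1` has not yet been measured. It differs from compound 3 by 1-amino-2,2-dimethylpropyl in place of 1-aminocyclopentyl on a saturated chain carbon bound to an amide-type nitrogen. Among the compounds with values here, two measured steps bear on this change. Exchanging one open chain for another, more branched one gave a 630-fold lower number from compound 1 to compound 2 (2.80 log units; beyond the scatter), and closing the chain into the ring of compound 3 added only a 2.5-fold lower number from compound 2 to compound 3 (0.39 log units; beyond the scatter). Compound 4 returns to an open chain, yet one branched more heavily than that of compound 2, so the expectation is a modest rise in the number relative to compound 3, on the order of a 2.6-fold higher number from compound 3 to compound 4 (0.42 log units; beyond the scatter). Compound 4 is therefore estimated at 1.5 nM in this assay, within a range of 0.3 nM to 8 nM.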

Compound 4, half-maximal effective concentration: 11 nM
For compound 4 the middle estimate is 7.3-fold (0.87 log units) below the measured one; measured number above the stated range.
By their numbers in this assay, from the lowest: compound 3; then compound 2; then compound 4; then compound 1.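

At this saturated chain carbon bound to an amide-type nitrogen, swapping the 1-aminocyclopentyl group for 1-amino-2,2-dimethylpropyl keeps the same count of heavy atoms, yet in this assay it gives a 19-fold higher number from compound 3 to compound 4 (1.29 log units; beyond the scatter) and is not a neutral exchange. More branching on the open chain does not simply lower the number, since tert-butyl in place of sec-butyl gives a 7.9-fold higher number from compound 2 to compound 4 (0.90 log units; beyond the scatter) even though tert-butyl in place of isobutyl still gives an 80-fold lower number from compound 1 to compound 4 (1.90 log units; beyond the scatter), so among these open chains sec-butyl gives the lowest number. Nothing measured here accounts for these differences.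

On these data alone, whether 1-aminocyclobutyl or 1-aminocyclohexyl would match the number of compound 3 stays open. So does the effect of the opposite configuration at the defined stereocentre of compound 4.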